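From 4-fluorobenzyl to 3,4-difluorobenzyl

This account rests on a few compounds, and the source may have more. Where it says the series, first, only, none or still open, it means among the compounds named here.

- compound 1 `CN(Cc1ccc(F)cc1)C(=O)c1cc2c(Cc3cccc(Cl)c3)n[nH]c2cc1O`: 410 nM
- compound 2 `Cc1cccc(Cc2n[nH]c3cc(O)c(C(=O)N(C)Cc4ccc(F)cc4)cc23)c1`: 590 nM

In a functional assay on A2780 cells (Homo sapiens) for antiproliferative activity, read by resazurin assay, with a stated time of 72 h (a lower number here means a stronger inhibitor, a higher number a weaker inhibitor), compound 2 gives 590 nM, which sits within the scatter of compound 1. Compound 3 `Cc1cccc(Cc2n[nH]c3cc(O)c(C(=O)N(C)Cc4ccc(F)c(F)c4)cc23)c1` changes compound 2 by one fluoro in place of hydrogen on an aromatic carbon. This turns 4-fluorobenzyl into 3,4-difluorobenzyl. Among the compounds with values here, the only measured step, a 1.4-fold higher number from compound 1 to compound 2 (0.16 log units; within the scatter), is a methyl in place of chloro at a different place, so it offers only a loose guide to size. Within the data shown here, no measured step touches the fluorobenzyl group, so no change beyond the scatter is expected, and the estimated step is a 1.1-fold lower number from compound 2 to compound 3 (0.05 log units; within the scatter). For compound 3 the expected value is 520 nM, with an estimated range of 230 nM to 1200 nM.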

Compound 3, half-maximal inhibitory concentration: 530 nM
Compound 3: the middle estimate sits 1.0-fold (0.01 log units) below what was measured, and the stated range covers the measured number.
By their numbers in this assay, from the lowest: compounds 1, 3 and 2 (each within the scatter of the next).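

Placing a fluoro on this aromatic carbon, ortho to the existing fluoro group, gives a 1.1-fold lower number from compound 2 to compound 3 (0.05 log units; within the scatter) in this assay. Within the data shown here, this is the first measured step at the fluorobenzyl group, and it shows that 3,4-difluorobenzyl can stand in for 4-fluorobenzyl with no change beyond the scatter. No supporting data bear on what lies behind this result. The compounds shown leave open whether a methoxy group or an amine on this same carbon, or a longer chain in place of the benzyl group, would shift the number beyond the scatter.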